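The compounds below may be only part of what the source reports. "The series", "measured", "known", "first", "only" and "open" are said of these compounds alone.

The shared core carries a sulfur-bound group that differs across the set. Compound 1 `O=S(=O)(O)c1ccc(F)c2ncc(I)cc12` holds a free acid, and in an assay for inhibition of methylcytosine dioxygenase TET2 (Homo sapiens), read by mass spectrometry, with stated times of 30 min and 1 h (a higher number here means a weaker inhibitor, a lower number a stronger inhibitor), compound 1 gives 2300 nM. Compound 2 `CCOS(=O)(=O)c1ccc(F)c2ncc(I)cc12` carries an ethyl group on that oxygen; in this assay compound 2 gives > 200000 nM, a limit of the assay rather than a number. Compound 3 `CCCCCOS(=O)(=O)c1ccc(F)c2ncc(I)cc12` carries a pentyl group there; in this assay compound 3 gives > 200000 nM, again only a limit. Two of the three values thus sit at the limit of > 200000 nM in this assay, at which 2 of the 3 values shown sit, so an at least 86-fold higher number from compound 1 to compound 2 (1.93 log units; beyond the scatter) and an at least 86-fold higher number from compound 1 to compound 3 (1.93 log units; beyond the scatter) are lower bounds, while a step that the two limits leave unreadable from compound 2 to compound 3. Compound 4 `O=S(=O)(c1ccc(F)c2ncc(I)cc12)N1CCCC1` differs from compound 3 by pyrrolidin-1-yl in place of pentyloxy on a sulfonyl sulfur. Because both alkyl replacements of the hydrogen gave an at least 86-fold higher number from compound 1 to compound 2 (1.93 log units; beyond the scatter) and an at least 86-fold higher number from compound 1 to compound 3 (1.93 log units; beyond the scatter), a group without that hydrogen is expected to stay weak, and the step of an at least 1.3-fold lower number from compound 3 to compound 4 (0.12 log units; that floor lies within the scatter) is expected to be unreadable or small. For compound 4 an estimate of 150000 nM is given, within 20000 nM to 200000 nM.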

Compound 4, half-maximal inhibitory concentration: > 200000 nM
Compound 4: a limit, no number (the forecaster's own chance of this, stated with the estimate: 60%); at least 1.3-fold (0.12 log units) between middle value and limit.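

In this assay, among the compounds shown here, hydroxy on the sulfonyl sulfur had so far been replaced only by chains bound through oxygen; pyrrolidin-1-yl, a ring bound through nitrogen, gives an at least 86-fold higher number from compound 1 to compound 4 (1.93 log units; beyond the scatter) as well. Among the four compounds, only compound 1, with hydroxy, gives a number. The steps among compound 2, compound 3 and compound 4 cannot be read, and all three stop at one assay limit: the limit of > 200000 nM in this assay, at which 3 of the 4 values shown sit.

Still open, going by these compounds, is whether an unsubstituted sulfonamide, with its amino group on the sulfur, or a carboxylic acid in place of the sulfonic acid would keep a measurable value.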